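A few compounds are considered here, and "the series" means these few. Any claim that something is new, unique, unknown or untested is made for them only; others in the source may bear on it.

Measured compounds in a functional assay on CHO cells for positive allosteric modulation of muscarinic acetylcholine receptor M5 (Homo sapiens), read by calcium flux; a lower number here means a smaller maximal response, a higher number a larger maximal response:
compound 1, `CCN(Cc1ccccc1)C(=O)C1CCN(S(=O)(=O)c2ccccc2)CC1`, 69%
compound 2, `CCN(Cc1ccccc1)C(=O)C1CCN(S(=O)(=O)c2ccc(OC)cc2)CC1`, 84%
compound 3, `CCN(Cc1ccccc1)C(=O)C1CCN(S(=O)(=O)c2ccccc2OC)CC1`, "not determined" (no result reported)

Compound 3 stands without a number: in this assay no result was reported for it, so its place among the measured compounds cannot be fixed. Among the compounds with values here, the only comparison with two numbers is that of compound 1 and compound 2, where a methoxy in place of hydrogen on an aromatic carbon gave a number 15 percentage points higher from compound 1 to compound 2 (beyond the scatter), a modest rise that lies beyond the scatter.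

Compound 4, `CCN(Cc1ccccc1)C(=O)C1CCN(S(=O)(=O)c2ccc(OC)c(OC)c2)CC1`, has not yet been measured. Its difference from compound 3 is 3,4-dimethoxyphenyl in place of 2-methoxyphenyl on a sulfonyl sulfur. The step from compound 1 to compound 2 bears on it only loosely: it shows that adding one methoxy to the ring on the sulfonyl sulfur was accompanied by a larger maximal response, but compound 4 carries two methoxy groups on that ring, and compound 3, the direct neighbour, gives no number to step from. The expectation for compound 4 in this assay is therefore an estimate resting on compound 2 rather than a computed step. Compound 4 is expected to give about 80%, within a range from 60% to 100%.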

Compound 4, largest response reached (reported as percent of maximum), in percent of the reference or control that the assay uses: 57%
Estimate against measurement, compound 4: 23 percentage points above, and the stated range ends above it.
By their numbers in this assay, from the lowest: compound 4; then compound 1; then compound 2.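

In this assay the ring on the sulfonyl sulfur does not answer to methoxy groups in one direction only: one more methoxy in place of hydrogen on an aromatic carbon, which turns compound 2 into the 3,4-dimethoxyphenyl compound, gave a number 27 percentage points lower from compound 2 to compound 4 (beyond the scatter) and so more than reversed the earlier rise. The 3,4-dimethoxyphenyl group in place of phenyl on the same sulfur gave a number 12 percentage points lower from compound 1 to compound 4 (beyond the scatter), which places the doubly substituted ring under the unsubstituted one, so the maximal response among these compounds does not climb with the number of methoxy groups, and compound 4 is the compound that goes against such a reading. Nothing measured here gives a reason for this fall.

As far as these compounds go, the steps to and from compound 3 cannot be read, so what the 2-methoxyphenyl group does on this sulfur stays unknown, and with it whether the place of a methoxy on the ring matters as much as their number. From the compounds shown here alone, it also remains open how the maximal response would move with an ethoxy group, a chlorine atom or an amine on this ring in place of methoxy.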